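From fluoro to methoxy: the step to compound 4

The compounds below may be only part of what the source reports. "The series", "measured", "known", "first", "only" and "open" are said of these compounds alone.

Measured in a functional assay on SGC-7901 cells (Homo sapiens) for antiproliferative activity, read by sulforhodamine B assay, with a stated time of 72 h (a higher number here means a weaker inhibitor, a lower number a stronger inhibitor), as follows:
- compound 1 `COc1ccccc1NC(=S)N/N=C/c1ccc2ccccc2n1` gives > 100000 nM (a limit of the assay)
- compound 2 `S=C(N/N=C/c1ccc2ccccc2n1)Nc1ccc(Cl)cc1` gives 87600 nM
- compound 3 `Fc1ccc(NC(=S)N/N=C/c2ccc3ccccc3n2)cc1` gives 32300 nM

Of the two values that are actual numbers, compound 3 has the lower, and its nearest neighbour is compound 2. Compound 4 `COc1ccc(NC(=S)N/N=C/c2ccc3ccccc3n2)cc1` carries methoxy in place of fluoro on an aromatic carbon, para to a large group (methoxy in place of fluoro on an aromatic carbon). Within the data shown here, two measured steps bear on this change. The halogen swap at the same place gives a 2.7-fold lower number from compound 2 to compound 3 (0.43 log units; beyond the scatter), so fluoro gives the lower number there. The closer comparison is an at least 3.0-fold lower number from compound 1 to compound 3 (0.49 log units; beyond the scatter), with 4-fluorophenyl in place of 2-methoxyphenyl, although compound 4 has 4-methoxyphenyl instead. Neither step measures a methoxy group at this place directly, so the expectation is loose. On the evidence of these two steps, a modest loss of potency is expected, namely a 2.2-fold higher number from compound 3 to compound 4 (0.34 log units; beyond the scatter). Compound 4 is estimated at 70000 nM, with an expected range of 20000 nM to 100000 nM.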

Compound 4, half-maximal inhibitory concentration: 89600 nM
For compound 4 the middle estimate is 1.3-fold (0.11 log units) below the measured one; low and high end bracket the measured number.
By their numbers in this assay, from the lowest: compound 3; then compounds 2 and 4 (each within the scatter of the next). At a limit, above all of these: compound 1.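

In this assay, methoxy in place of fluoro on an aromatic carbon, para to a large group, gives a 2.8-fold higher number from compound 3 to compound 4 (0.44 log units; beyond the scatter), while methoxy in place of chloro gives a 1.0-fold higher number from compound 2 to compound 4 (0.01 log units; within the scatter), so among these three groups at this place only fluoro stands apart. Compound 1 stands at a limit of the assay: the limit of > 100000 nM in this assay, at which 1 of the 4 values shown sits. Going by these compounds, the change to 4-methoxyphenyl in place of 2-methoxyphenyl therefore reads only as an at least 1.1-fold lower number from compound 1 to compound 4 (0.04 log units; that floor lies within the scatter), and the size of the effect of where the methoxy sits remains unknown.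

The compounds shown leave open whether an amine, a hydroxyl or a longer alkoxy chain at this place would stand with fluoro or with chloro and methoxy. They also leave open whether fluoro on another carbon of this ring would match compound 3.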